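The source may report more compounds than this note shows. Statements on the series, on what has been measured and on what is new or still open speak of the compounds shown alone.

Four compounds share one core. Compound 1 is `CC(=O)N1CCN(S(=O)(=O)c2ccc(F)cc2)C(CO)C1`, compound 2 is `CC(=O)OCC1CN(S(=O)(=O)c2ccc(F)cc2)CCN1C(C)=O`, compound 3 is `COCC1CN(C(C)=O)CCN1S(=O)(=O)c1ccc(F)cc1`, and compound 4, not yet measured, is `CCOC(=O)C1CN(S(=O)(=O)c2ccc(F)cc2)CCN1C(C)=O`. In a physicochemical assay for metabolic stability, read by LC-MS, in phosphate buffer, tested at 1 uM (on this read-out lower numbers stand for a shorter-lived compound and higher numbers for a longer-lived compound), compound 1 gives >= 4 h, which is a limit of the assay rather than a number. In this assay compound 2 likewise gives >= 4 h, again only a limit. Compound 3 gives >= 4 h, once more a limit. Within the data shown here, the one single-point step among the measured compounds, a step that the two limits leave unreadable from compound 1 to compound 3, therefore cannot be read in size, since the limit of >= 4 h in this assay, at which 3 of the 3 values shown sit, holds all three values. Compound 2 thus stands with the other two at that limit, with no number of its own.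

Compound 4 differs from compound 2 by ethoxycarbonyl in place of acetoxymethyl on a saturated ring carbon. Among the measured compounds shown here, no measured step speaks to such a change, and the only step that exists, from compound 1 to compound 3, is unreadable, so no direction beyond the scatter can be expected. Compound 4 is estimated to give 4 h in this assay, between 2 h and 8 h. The estimated step is a number no higher from compound 2 to compound 4 (the limit leaves the size open).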

Compound 4, half-life: >= 4 h
Compound 4 gave a limit, no number; the forecaster's own chance of this, stated with the estimate: 70%; the middle value lies on the limit itself.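

Compound 2 and compound 4 both sit at a limit in this assay, so the step between them cannot be read in size: the limit of >= 4 h in this assay, at which 4 of the 4 values shown sit.

As far as these compounds go, how long each of the four compounds actually lasts in this assay, and whether ethoxycarbonyl in place of acetoxymethyl changes that at all, stays open.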